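Compound 3 to compound 4: a larger sulfonyl side group

The compounds below may be only part of what the source reports. "The series", "measured", "known", "first", "only" and "open" are said of these compounds alone.

Measured so far in an ADME assay on L02 cells (Homo sapiens) for cytotoxicity, read by MTT assay; a higher number here means a weaker inhibitor, a lower number a stronger inhibitor
- compound 1 `COc1ccc(/C=C/C(=O)c2ccc(OC)c3c2OC(C)(C)C=C3)cc1OCCCN(C)C` gives 8600 nM
- compound 2 `C=CC(=O)Oc1cc(/C=C/C(=O)c2ccc(OC)c3c2OC(C)(C)C=C3)ccc1OC` gives > 10000 nM, a limit and not a number
- compound 3 `COc1ccc(/C=C/C(=O)c2ccc(OC)c3c2OC(C)(C)C=C3)cc1CS(C)(=O)=O` gives > 10000 nM, also a limit and not a number

Compound 3 has no exact value, so it sits at the limit of > 10000 nM in this assay, at which 2 of the 3 values shown sit, and cannot be ranked more finely. Only compound 1 has an exact value.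

Compound 4 `COc1ccc(/C=C/C(=O)c2ccc(OC)c3c2OC(C)(C)C=C3)cc1OS(=O)(=O)Cc1ccccc1` has not yet been measured. It carries (benzylsulfonyl)oxy in place of the (methylsulfonyl)methyl of compound 3, on an aromatic carbon ortho to a methoxy group, and the rest of the molecule is unchanged: (benzylsulfonyl)oxy in place of (methylsulfonyl)methyl on an aromatic carbon.

Two measured changes at this same place bear most directly on the swap. They are an at least 1.1-fold higher number from compound 1 to compound 3 (0.06 log units; that floor lies within the scatter) and an at least 1.1-fold higher number from compound 1 to compound 2 (0.06 log units; that floor lies within the scatter), and each gives only a floor, not a full size. The third pair shows a step that the two limits leave unreadable from compound 2 to compound 3. None of these steps therefore shows a change beyond the scatter, although the true sizes could be larger.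

The step expected here is a step that the limit leaves unreadable from compound 3 to compound 4, and no clear shift beyond the scatter is expected in this assay on this evidence. Compound 4 is estimated at 12000 nM, with an expected range from 6000 nM to 25000 nM, and a report of only a limit is quite likely.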

Compound 4, half-maximal inhibitory concentration: > 10000 nM
Compound 4: only a limit was reported; the forecaster's own chance of this, stated with the estimate: 65%; the middle value does not contradict the limit.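

In this assay compound 4 gives > 10000 nM, which is a limit of the assay and not a number. Even with the larger (benzylsulfonyl)oxy, which brings a six-membered aromatic ring of carbon only to this aromatic carbon ortho to a methoxy group, the result stays at the same limit, so a third kind of group here gives no exact value: the limit of > 10000 nM in this assay, at which 3 of the 4 values shown sit. Among these compounds, the steps joining compound 4 with compound 2 and with compound 3 cannot be read, and the one readable comparison is an at least 1.1-fold higher number from compound 1 to compound 4 (0.06 log units; that floor lies within the scatter), so it shows no change beyond the scatter.

Only compound 1, which carries 3-(dimethylamino)propoxy, has an exact value in this set, 8600 nM. From the compounds shown here alone, how far compound 2, compound 3 and compound 4 lie from the limit remains unknown. Also open, going by these compounds, is whether a different group at this position, such as a carboxylic acid or a 2-(dimethylamino)ethoxy chain, would give an exact value that could be compared with compound 1.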